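Working notes: side-chain swap from compound 2 to compound 3

The source may hold more compounds than are shown below. What is called first, only, known or untested is meant among the compounds shown, and "the series" means these compounds.

Values in a functional assay on HCT-116 cells (Homo sapiens) for antiproliferative activity, read by MTT assay, with a stated time of 72 h; on this read-out higher numbers stand for weaker inhibition and lower numbers for stronger inhibition:
- Compound 1 `C=CC(=O)N(CC(=O)NC1COC1)c1nc(-c2ccccc2)cs1`: 20800 nM
- Compound 2 `C=CC(=O)N(Cc1cc(C)no1)c1nc(-c2ccccc2)cs1`: > 30000 nM (a limit of the assay)
- Compound 3 `C=CC(=O)N(Cc1cccnc1)c1nc(-c2ccccc2)cs1`: not yet measured

Compound 2 has no number in this assay, only a limit: > 30000 nM. The two values shown include (the limit of > 30000 nM in this assay, at which 1 of the 2 values shown sits).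

The change to compound 3 is pyridin-3-yl in place of 3-methyl-1,2-oxazol-5-yl on a saturated chain carbon bound to an amide-type nitrogen. In words, this places pyridin-3-yl in place of 3-methyl-1,2-oxazol-5-yl on a saturated chain carbon bound to an amide-type nitrogen.

For the measured compounds named here, one measured step bears on this place: an at least 1.4-fold higher number from compound 1 to compound 2 (0.15 log units; that floor lies within the scatter). It puts 3-methyl-1,2-oxazol-5-yl in place of (oxetan-3-yl)carbamoyl, and its floor lies within the scatter. Going by the values given here, no measured compound carries pyridin-3-yl, so the size of this swap rests on that single step. A clear gain or loss is not expected, and compound 3 may also return only a limit.

The expected change in this assay is an at least 1.2-fold lower number from compound 2 to compound 3 (0.07 log units; that floor lies within the scatter), which would be no step beyond the scatter. For compound 3 the estimate is 25000 nM, with an expected range from 9000 nM to 60000 nM.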

Compound 3, half-maximal inhibitory concentration: > 30000 nM
Compound 3 gave a limit, no number; the forecaster's own chance of this, stated with the estimate: 45%; at least 1.2-fold (0.07 log units) between middle value and limit.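

In this assay, pyridin-3-yl on a saturated chain carbon bound to an amide-type nitrogen gives no number either: compound 3 reads > 30000 nM, which is a limit of the assay. With (oxetan-3-yl)carbamoyl replaced by pyridin-3-yl, the readable step is an at least 1.4-fold higher number from compound 1 to compound 3 (0.15 log units; that floor lies within the scatter), so a second aromatic ring at this place now gives only a floor within the scatter, like the step to 3-methyl-1,2-oxazol-5-yl. The step from compound 2 to compound 3 cannot be read, and the two aromatic rings can be told apart only as far as this line goes: the limit of > 30000 nM in this assay, at which 2 of the 3 values shown sit.

For the compounds shown here, compound 1, at 20800 nM, is the only compound here with a number, but the floors of its steps lie within the scatter, so no order among the three compounds is established. Going by these compounds, it remains open whether an amine, a carboxylic acid or a longer chain at this place would give a clearly lower number than compound 1, and how far compound 2 and compound 3 lie past their limits.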